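Moving the methyl to 3-methylpiperidin-1-yl

The source may report more compounds than this note shows. Statements on the series, on what has been measured and on what is new or still open speak of the compounds shown alone.

Within the data shown here, in an ADME assay on HeLa cells (Homo sapiens) for cytotoxicity (on this read-out higher numbers stand for weaker inhibition and lower numbers for stronger inhibition), compound 1 `Cc1ncc([N+](=O)[O-])n1CCSC(=S)N1CCC(C)CC1` gives 190 ug/mL as the only exact number so far. Compound 2 `Cc1ncc([N+](=O)[O-])n1CCSC(=S)N1CCC(OC(=O)C(Cl)Cl)CC1` reads > 1000 ug/mL and this value is a limit of the assay. Compound 3 `Cc1ncc([N+](=O)[O-])n1CCSC(=S)N1CCCC(C)C1` differs from compound 1 thus: 3-methylpiperidin-1-yl in place of 4-methylpiperidin-1-yl on a thiocarbonyl carbon. Among the measured compounds shown here, the one measured step of an at least 5.2-fold higher number from compound 1 to compound 2 (0.72 log units; beyond the scatter) replaces the methyl with ((dichloromethyl)carbonyl)oxy and does not move it, so it bears only loosely here. No step beyond the scatter is therefore expected in this assay. The estimated step is no change at the digits printed from compound 1 to compound 3 (within the scatter). The estimate for compound 3 is 190 ug/mL with an expected range from 100 ug/mL to 360 ug/mL.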

Compound 3, half-maximal inhibitory concentration: 170 ug/mL
For compound 3 the middle estimate is 1.1-fold (0.05 log units) above the measured one; the range from low to high includes it.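

In this assay, the exchange gives a 1.1-fold lower number from compound 1 to compound 3 (0.05 log units; within the scatter) when 3-methylpiperidin-1-yl replaces 4-methylpiperidin-1-yl on the thiocarbonyl carbon. Unlike the earlier step, which replaced the methyl with another group, this change keeps the same atoms and moves only the methyl, and the two placements cannot be told apart on this read-out. No measured property available here bears on this result.

Going by these compounds, the effect of 2-methylpiperidin-1-yl at this position remains open. So does whether the same insensitivity would hold for a carboxylic acid or a primary amine moved in the same way around the ring.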